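Hydroxy for methoxy alongside two trifluoromethyl groups

The source may hold more compounds than are shown below. What is called first, only, known or untested is meant among the compounds shown, and "the series" means these compounds.

Of the compounds shown here, two have been tested in a functional assay on SR cells (Homo sapiens) for inhibition, read by sulforhodamine B assay, with a stated time of 48 h; on this read-out lower numbers stand for higher toxicity in this test and higher numbers for lower toxicity in this test. Compound 1 `O=C(Nc1cccc(-n2cc(-c3ccncc3)c(-c3ccc(Cl)c(O)c3)n2)c1)Nc1cccc(C(F)(F)F)c1` bears the 4-chloro-3-hydroxyphenyl group; in this assay compound 1 gives > 32500 nM, which is a limit of the assay and not a number (the limit of > 32500 nM in this assay, at which 1 of the 2 values shown sits). Compound 2 `COc1cc(-c2nn(-c3cccc(NC(=O)Nc4cc(C(F)(F)F)cc(C(F)(F)F)c4)c3)cc2-c2ccncc2)ccc1Cl` bears the 4-chloro-3-methoxyphenyl group; in this assay compound 2 gives > 50000 nM, again a limit rather than a number (the limit of > 50000 nM in this assay, at which 1 of the 2 values shown sits). Going by the values given here, compound 2 thus stands at a limit, as does the only other value shown, and no measured step between them exists. Compound 3 `O=C(Nc1cccc(-n2cc(-c3ccncc3)c(-c3ccc(Cl)c(O)c3)n2)c1)Nc1cc(C(F)(F)F)cc(C(F)(F)F)c1` differs from compound 2 by hydrogen in place of methyl on an oxygen on an aromatic ring. With both measured compounds at limits, the step from compound 2 to compound 3 is expected to be none beyond the scatter, a number no higher from compound 2 to compound 3 (the limit leaves the size open). Compound 3 is estimated at 50000 nM, within 20000 nM to 120000 nM, most likely reported as a limit.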

Compound 3, concentration lethal to 50% of the cells: > 50000 nM
Compound 3 gave a limit, no number; the forecaster's own chance of this, stated with the estimate: 80%; the middle value lies on the limit itself.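

Compound 1, compound 2 and compound 3 all stand at limits rather than numbers, so neither the step between compound 2 and compound 3 nor that between compound 1 and compound 3 can be read. On these data alone, whether methoxy to hydroxy or the added trifluoromethyl changes toxicity at all stays open.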